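This account rests on a few compounds, and the source may have more. Where it says the series, first, only, none or still open, it means among the compounds named here.

Among the compounds with values here, in a functional assay on SW-620 cells (Homo sapiens) for antiproliferative activity, with a stated time of 48 h (on this read-out higher numbers stand for weaker inhibition of growth and lower numbers for stronger inhibition of growth), compound 3 `COc1ccc(C2CC(c3cc(Cl)c(C)cc3O)=NN2c2ccc(S(N)(=O)=O)cc2)cc1OC` gives 4080 nM, the second highest of the three numbers so far. Compound 1 `Cc1cc(O)c(C2=NN(c3ccc(S(N)(=O)=O)cc3)C(c3ccccc3O)C2)cc1Cl` gives 1760 nM in this assay, and compound 2 `Cc1cc(O)c(C2=NN(c3ccc(S(N)(=O)=O)cc3)C(/C=C/c3ccccc3)C2)cc1Cl` gives 11700 nM. The steps among these three all exchange the whole group on the saturated ring carbon: a 2.3-fold higher number from compound 1 to compound 3 (0.37 log units; beyond the scatter), a 2.9-fold lower number from compound 2 to compound 3 (0.46 log units; beyond the scatter) and a 6.6-fold higher number from compound 1 to compound 2 (0.82 log units; beyond the scatter).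

Compound 4 `COc1ccc(C2CC(c3cc(Cl)c(C)cc3O)=NN2c2ccc(S(N)(=O)=O)cc2)c(OC)c1OC` differs from compound 3 in one place: methoxy in place of hydrogen on an aromatic carbon. No measured step adds a single methoxy to an aryl group that is already present; the three steps shown swap one aryl or alkenyl group for another, and they are modest. Within the data shown here, no measured step therefore bears directly on this change, and the expectation rests on the small size of the nearest swaps.

For compound 4 the step is expected to be a 1.0-fold lower number from compound 3 to compound 4 (0.01 log units; within the scatter), most likely within the scatter. Compound 4 is estimated at 4000 nM in this assay, with a range from 1500 nM to 11000 nM.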

Compound 4, concentration for 50% growth inhibition: 3350 nM
Compound 4: the middle estimate sits 1.2-fold (0.08 log units) above what was measured; the range from low to high includes it.
By their numbers in this assay, from the lowest: compounds 1, 4 and 3 (each within the scatter of the next, the first and the last beyond it); then compound 2.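

In this assay, methoxy in place of hydrogen on this aromatic carbon, ortho to a large group, turns 3,4-dimethoxyphenyl into 2,3,4-trimethoxyphenyl and gives a 1.2-fold lower number from compound 3 to compound 4 (0.09 log units; within the scatter), so this added group leaves no readable mark on the number. The wider swaps on the saturated ring carbon now separate: replacing 2-hydroxyphenyl gives a 1.9-fold higher number from compound 1 to compound 4 (0.28 log units; within the scatter), whereas replacing 2-phenylethenyl gives a 3.5-fold lower number from compound 2 to compound 4 (0.54 log units; beyond the scatter). No measurement to hand accounts for these results.

The compounds shown leave open whether an amine or a carboxylic acid on this aromatic carbon would move the number as little as methoxy does, and whether a longer chain such as ethoxy would. They also leave open how the same methoxy would read on the 2-hydroxyphenyl group of compound 1.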